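Trimming the Urea Substituent in a Receptor Antagonist Series

The compounds below may be only part of what the source reports. "The series", "measured", "known", "first", "only" and "open" are said of these compounds alone.

Compound 2 `COc1ccc([N+](=O)[O-])cc1CSc1nc2cc(NC(=O)NC(C)C)ccc2n1C(C)C` is the weaker of the two measured entries in an assay on isolated protein for inhibition of Gonadotropin-releasing hormone receptor (Homo sapiens); a higher number here means a weaker inhibitor, a lower number a stronger inhibitor; in that assay compound 2 gives 600 nM, whereas compound 1 `COc1ccc([N+](=O)[O-])cc1CSc1nc2cc(NC(=O)C(C)(C)C)ccc2n1C(C)C` gives 180 nM. For the measured compounds named here, the one measured step, a 3.3-fold higher number from compound 1 to compound 2 (0.52 log units; beyond the scatter), exchanges the tert-butyl for an isopropylamino on the carbonyl carbon. Compound 3 `CNC(=O)Nc1ccc2c(c1)nc(SCc1cc([N+](=O)[O-])ccc1OC)n2C(C)C` has not yet been measured; it differs from compound 2 in methyl in place of isopropyl on an amide-type nitrogen. Going by the values given here, no measured step alters the group on that amide-type nitrogen, so the guidance is only indirect: the step of a 3.3-fold higher number from compound 1 to compound 2 (0.52 log units; beyond the scatter) shows that this end of the molecule can move the number, but it does not tell in which direction a shorter alkyl on the nitrogen would push it. The expected change is therefore small, a 1.3-fold higher number from compound 2 to compound 3 (0.12 log units; within the scatter), and carries a wide uncertainty. Compound 3 is estimated at 800 nM in this assay, between 300 nM and 2500 nM.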

Compound 3, half-maximal inhibitory concentration: 3300 nM
For compound 3 the middle estimate is 4.1-fold (0.62 log units) below the measured one; the whole stated range lies below it.
By their numbers in this assay, from the lowest: compound 1; then compound 2; then compound 3.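

In this assay, the group on the amide-type nitrogen itself moves the number: methyl in place of isopropyl gives a 5.5-fold higher number from compound 2 to compound 3 (0.74 log units; beyond the scatter) and so the shorter alkyl goes with the weaker inhibitor. Methylamino in place of tert-butyl on the carbonyl carbon gives an 18-fold higher number from compound 1 to compound 3 (1.26 log units; beyond the scatter) and across these three compounds the number rises in the order tert-butyl, isopropylamino, methylamino, with no compound going against that order. Nothing shown here accounts for this change.

As far as these compounds go, whether a butyl chain or a cyclopentyl ring on that nitrogen would bring the number down further than isopropyl does remains open. Also open, from the compounds shown here alone, is whether an unsubstituted amino group would continue the rise seen with methyl, or whether a dimethylamino group, which leaves no hydrogen on that nitrogen, would behave differently from either.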